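Anilide to Pyridinylamide on a Shared Dimethoxy Core

The source may report more compounds than this note shows. Statements on the series, on what has been measured and on what is new or still open speak of the compounds shown alone.

Three compounds have been measured in a functional assay on the whole organism (strain Wistar) for inhibition, with Rattus norvegicus as the target, read by paw edema, with a stated time of 1 h, at a dose of 100 mg/kg; on this read-out higher numbers stand for more inhibition at the one dose given (going by the name of the read-out) and lower numbers for less inhibition:

compound 1, `COc1cc2c(cc1OC)C(CC(=O)O)CC2`: 18.8%
compound 2, `COc1cc2c(cc1OC)C(CC(=O)Nc1ccccc1)CC2`: 31.3%
compound 3, `COc1cc2c(cc1OC)C(CC(=O)Nc1ccc(C)cc1)CC2`: 34.4%

Compound 3 holds the highest of the three numbers. Its gap to compound 2, a number 3.1 percentage points higher from compound 2 to compound 3 (within the scatter), lies within the scatter, so the two cannot be ranked; its gap to compound 1, a number 15.6 percentage points higher from compound 1 to compound 3 (beyond the scatter), lies beyond it, as does the step of a number 12.5 percentage points higher from compound 1 to compound 2 (beyond the scatter). Both amides thus sit modestly above the free acid, while the methyl on the aromatic carbon changes nothing that can be trusted.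

Compound 4, `COc1cc2c(cc1OC)C(CC(=O)Nc1ccccn1)CC2`, has not yet been measured in this assay. It differs from compound 3 by pyridin-2-yl in place of 4-methylphenyl on an amide-type nitrogen. Within the data shown here, no measured step exchanges the aryl ring on the amide nitrogen for a ring carrying a hetero atom; the only step touching that ring, a number 3.1 percentage points higher from compound 2 to compound 3 (within the scatter), was within the scatter. The two anilides together suggest that the amide as such carries the modest gain over compound 1.

Compound 4 is therefore expected to stay close to compound 3, with a step of a number 3.4 percentage points lower from compound 3 to compound 4 (within the scatter), none beyond the scatter. The estimate for compound 4 in this assay is 31%, in a range from 17% to 45%.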

Compound 4, a percentage reported as inhibition, in the whole organism at one dose (the size of the read-out at that dose, not a potency): 25%
Compound 4: middle estimate off by 6 percentage points, on the high side; measured number inside the range.
By their numbers in this assay, from the lowest: compounds 1, 4, 2 and 3 (each within the scatter of the next, the first and the last beyond it).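

Among these compounds, compound 4 is the only compound here with a hetero atom in the ring on the amide-type nitrogen, and in this assay this exchange cannot be told apart from either anilide: the step is (a number 9.4 percentage points lower from compound 3 to compound 4 (within the scatter)) against the 4-methylphenyl amide and (a number 6.3 percentage points lower from compound 2 to compound 4 (within the scatter)) against the phenyl amide. The new information lies in the comparison with the free acid, (a number 6.2 percentage points higher from compound 1 to compound 4 (within the scatter)), which stays within the scatter, whereas the steps to the two anilides do not, so the reading that the amide as such carries the gain holds for compound 2 and compound 3 but not for compound 4. Nothing at hand bears on what lies behind this result.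

Compound 4 thus cannot be separated from any of the other three, and the single pyridine leaves the role of the ring on the amide-type nitrogen unsettled. As far as these compounds go, whether pyridin-3-yl, pyridin-4-yl or a saturated cyclohexyl ring at this nitrogen would stand clearly apart from the anilides or from the acid remains open.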